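From bromo to trifluoromethyl at the phenyl ring: compound 3

This account rests on a few compounds, and the source may have more. Where it says the series, first, only, none or still open, it means among the compounds named here.

In a functional assay on muscle tissue for agonist activity at histamine H2 receptor (Cavia porcellus) (on this read-out higher numbers stand for larger maximal responses and lower numbers for smaller maximal responses), compound 1 `N=C(NCCCc1c[nH]cn1)NCCC(c1ccccc1)c1ccccn1` gives 0.7. Among the measured compounds shown here, compound 2 `N=C(NCCCc1c[nH]cn1)NCCC(c1ccc(Br)cc1)c1ccccn1` gives 0.4, the lower of the two measured values, and the only measured step, a number 0.30 lower from compound 1 to compound 2 (beyond the scatter), is a modest loss on adding bromo. Compound 3 `N=C(NCCCc1c[nH]cn1)NCCC(c1ccc(C(F)(F)F)cc1)c1ccccn1` differs from compound 2 by trifluoromethyl in place of bromo on an aromatic carbon. For the measured compounds named here, no measured step exchanges one group for another on this aromatic carbon, so the bromo step offers only indirect guidance; the trifluoromethyl group is expected to behave much like bromo here. The expected step is no change at the digits printed from compound 2 to compound 3 (within the scatter), within the scatter. Compound 3 is therefore estimated at 0.4, between 0.2 and 0.6.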

Compound 3, intrinsic activity: the largest response reached, as a fraction of the reference agonist's: 0.9
Compound 3: middle estimate off by 0.50, on the low side; measured number outside the range, above it.
By their numbers in this assay, from the lowest: compound 2; then compound 1; then compound 3.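

At this aromatic carbon, para to a large group, the group itself decides the outcome in this assay: the change reads a number 0.50 higher from compound 2 to compound 3 (beyond the scatter) and, against the unsubstituted phenyl, a number 0.20 higher from compound 1 to compound 3 (beyond the scatter) on replacing hydrogen. A substituent here therefore need not lower the maximal response, since bromo in compound 2 and trifluoromethyl in compound 3 move it in opposite directions from compound 1. No measured evidence accounts for this divergence. Still open, as far as these compounds go, is how a methoxy group, an amine or a carboxylic acid would read at this carbon, and whether chloro or fluoro falls with bromo or with trifluoromethyl.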